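The source may hold more compounds than are shown below. What is called first, only, known or untested is meant among the compounds shown, and "the series" means these compounds.

Measured in a functional assay on HCT-116 cells (Homo sapiens) for antiproliferative activity, read by MTT assay, with a stated time of 48 h; on this read-out lower numbers stand for stronger inhibition and higher numbers for weaker inhibition:
- compound 1, `CC(CCO)n1cnc2c(Cl)nc(F)nc21`: 19800 nM
- compound 2, `CC(CCO)n1cnc2c(Cl)ncnc21`: > 50000 nM
- compound 3, `CCCCCC(CCO)n1c(Br)nc2c(Cl)ncnc21`: 18300 nM

Compound 2 stands outside the numbers: in this assay compound 2 returns only a limit, (the limit of > 50000 nM in this assay, at which 1 of the 3 values shown sits), and no number. Going by the values given here, the one step that reaches it, an at least 2.5-fold higher number from compound 1 to compound 2 (0.40 log units; beyond the scatter), is a loss of activity on removing the fluoro. Compound 3 carries a longer chain on the saturated carbon and a bromo on the core, and in this assay compound 3 gives 18300 nM; it differs from compound 2 in two places, so no single step can be read between them.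

Compound 4, `CCCCCCCCC(CCO)n1cnc2c(Cl)ncnc21`, has not been measured. Its change from compound 2 is heptyl in place of hydrogen on a saturated chain carbon, two bonds along the chain from an aromatic nitrogen. Among the compounds with values here, no measured step isolates a chain extension of this kind; the only hint is that compound 3, which also bears a long chain, sits within the numbered range. The expected direction in this assay is therefore toward a lower number, of a size that cannot be fixed from the steps shown, and a result that again reports only a limit remains quite possible.

Compound 4 is expected to give about 30000 nM in this assay, estimated between 10000 nM and 100000 nM. The step this implies, an at least 1.6-fold lower number from compound 2 to compound 4 (0.22 log units; that floor lies within the scatter), is an expectation only.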

Compound 4, half-maximal inhibitory concentration: 1650 nM
Estimate against measurement, compound 4: 18-fold (1.26 log units) above; the whole stated range lies above it.
By their numbers in this assay, from the lowest: compound 4; then compounds 3 and 1 (each within the scatter of the next). At a limit, above all of these: compound 2.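

Heptyl in place of hydrogen on a saturated chain carbon, two bonds along the chain from an aromatic nitrogen, is the first single change at this position that can be read in the series, and in this assay it gives an at least 30-fold lower number from compound 2 to compound 4 (1.48 log units; beyond the scatter). Compound 2 stands at a limit, which makes the size of this step a floor and not a measured gap: the limit of > 50000 nM in this assay, at which 1 of the 4 values shown sits.

The core of compound 4 is that of compound 2 unchanged, which ties this gain to the heptyl alone, whereas the longer chain of compound 3 comes together with a bromo on the core and cannot be read apart from it.

As far as these compounds go, whether a propyl or a still longer chain such as decyl on this carbon would give a lower or a higher number than heptyl stays open, as does the effect of an amine or a carboxylic acid at the end of the chain. Also open, from the compounds shown here alone, is whether the fluoro of compound 1 and the heptyl of compound 4 would add up on one core.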